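A few compounds are considered here, and "the series" means these few. Any claim that something is new, unique, unknown or untested is made for them only; others in the source may bear on it.

The measured compounds:

Compound 1 `Cc1nn(C)c(Oc2cccc(F)c2)c1/C=N\CCCCCOc1cc2oc(=O)cc(C)c2cc1Cl` gives 9870 nM in a functional assay on U-87MG ATCC cells for antiproliferative activity against U-87 MG (Homo sapiens), read by MTT assay, with a stated time of 72 h; on this read-out higher numbers stand for weaker inhibition and lower numbers for stronger inhibition.
Compound 2 `Cc1nn(C)c(Oc2ccc(Cl)cc2)c1/C=N\CCCCCOc1cc2oc(=O)cc(C)c2cc1Cl` gives 18700 nM in this assay.
Compound 3 `Cc1nn(C)c(Oc2cccc(F)c2)c1/C=N\CCCCCCOc1cc2oc(=O)cc(C)c2cc1Cl` gives > 25000 nM in this assay, which is a limit of the assay and not a number.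

Compound 3 therefore stands at the limit of > 25000 nM in this assay, at which 1 of the 3 values shown sits. Going by the values given here, of the three compounds it is the only one for which no number is available, so it can be placed no more precisely than that limit.

Compound 4 `Cc1nn(C)c(Oc2cccc(F)c2F)c1/C=N\CCCCCCOc1cc2oc(=O)cc(C)c2cc1Cl` differs from compound 3 by fluoro in place of hydrogen on an aromatic carbon. Among the compounds with values here, the one measured step between neighbours, a 1.9-fold higher number from compound 1 to compound 2 (0.28 log units; within the scatter), concerns a different change on the same phenoxy ring and was within the scatter. Within the data shown here, no measured step adds a fluoro in the place concerned here, so there is nothing to support a shift in either direction beyond the scatter for compound 4 in this assay.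

Since compound 3 is already at the limit, compound 4 is expected to return a limit as well. The estimate for compound 4 is 30000 nM, with a range from 15000 nM to 70000 nM. This estimate means a step that the limit leaves unreadable from compound 3 to compound 4, which is expected to stay within the scatter.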

Compound 4, half-maximal inhibitory concentration: > 25000 nM
Compound 4: no number, only a limit; the forecaster's own chance of this, stated with the estimate: 70%; the middle value lies beyond the limit too.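

In this assay compound 3 and compound 4 both stand at a limit and not at a number, so no step can be read between them: the limit of > 25000 nM in this assay, at which 2 of the 4 values shown sit. The compounds shown leave open how far either lies past that limit, and whether fluoro in this place changes the antiproliferative read-out at all.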